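Replacing 3-hydroxypropyl with allyl in compound 2

A few compounds are considered here, and "the series" means these few. Any claim that something is new, unique, unknown or untested is made for them only; others in the source may bear on it.

In a functional assay on HCT-116 cells (Homo sapiens) for antiproliferative activity, read by sulforhodamine B assay, with a stated time of 72 h (on this read-out higher numbers stand for weaker inhibition and lower numbers for stronger inhibition), compound 1 `Cn1ncc(Cl)c1-c1cc(C(=O)N[C@@H]2CN[C@H](CC(O)CO)C[C@H]2c2ccc(F)c(F)c2)oc1Cl` gives 800 nM as its reading, compound 2 `Cn1ncc(Cl)c1-c1cc(C(=O)N[C@@H]2CN[C@H](CCCO)C[C@H]2c2ccc(Cl)c(Cl)c2)oc1Cl` gives 510 nM and compound 3 `Cn1ncc(Cl)c1-c1cc(C(=O)N[C@@H]2CNCC[C@H]2c2ccc(C(F)(F)F)cc2)oc1Cl` gives 280 nM on the same scale. Compound 2 thus lies within the scatter of both other compounds. Compound 4 `C=CC[C@@H]1C[C@@H](c2ccc(Cl)c(Cl)c2)[C@H](NC(=O)c2cc(-c3c(Cl)cnn3C)c(Cl)o2)CN1` has not yet been measured. It differs from compound 2 by vinyl in place of 2-hydroxyethyl on a saturated chain carbon bound to a saturated ring carbon in one place, vinyl in place of 2-hydroxyethyl on a saturated chain carbon bound to a saturated ring carbon. Within the data shown here, no measured pair isolates this change, so the step of a 1.2-fold lower number from compound 2 to compound 4 (0.08 log units; within the scatter) is expected to stay within the scatter in this assay and to have no firm direction. Compound 4 is estimated at 420 nM with a likely range from 150 nM to 1100 nM in this measurement.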

Compound 4, half-maximal inhibitory concentration: 780 nM
Beside the measured number, compound 4's estimate is 1.9-fold (0.27 log units) below it; low and high end bracket the measured number.
By their numbers in this assay, from the lowest: compounds 3, 2, 4 and 1 (each within the scatter of the next, the first and the last beyond it).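

In this assay, among these compounds, this pair is the first to isolate the change at this place, and the step of a 1.5-fold higher number from compound 2 to compound 4 (0.18 log units; within the scatter) shows that swapping 3-hydroxypropyl for allyl on a saturated chain carbon bound to a saturated ring carbon gives no firm shift. The reading therefore stays within the scatter even though the hydrogen-bond donor and acceptor of the 2-hydroxyethyl part leave with it. Nothing measured here explains this result. As far as these compounds go, whether an amine, a carboxylic acid or a longer chain at this place would move the reading beyond the scatter remains open.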